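Ethyl ester of compound 1: expected dose

The compounds below may be only part of what the source reports. "The series", "measured", "known", "first", "only" and "open" are said of these compounds alone.

Compound 1 `CSc1ccccc1-c1ncc(C(=O)O)c(=O)[nH]1` is read in a functional assay on the whole organism (strain Sprague-Dawley) for inhibition, with Rattus norvegicus as the target, with a stated time of 10 min (a lower number here means that less compound is needed, a higher number that more compound is needed for the effect), only as a limit, > 20 mg/kg. By the limit of > 20 mg/kg in this assay, at which 1 of the 2 values shown sits, compound 1 stands at the edge of what the runs recorded, so its place among the numbers shown is open. Compound 2 `CCSc1ccccc1-c1ncc(C(=O)O)c(=O)[nH]1` gives 25 mg/kg in this assay. The step that the limit leaves unreadable from compound 1 to compound 2 is the only measured one and does not touch the carboxy group. Compound 3 `CCOC(=O)c1cnc(-c2ccccc2SC)[nH]c1=O` differs from compound 1 by ethyl in place of hydrogen on an oxygen next to a carbonyl group. Among the measured compounds shown here, no measured step covers this change, so no direction beyond the scatter is expected. For compound 3 the expected dose in this assay is 25 mg/kg, between 8 mg/kg and 80 mg/kg. The expected step is a step that the limit leaves unreadable from compound 1 to compound 3.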

Compound 3, dose for 50% inhibition: > 25 mg/kg
Compound 3: a limit, no number (the forecaster's own chance of this, stated with the estimate: 45%); the middle value sits exactly at the limit.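

Compound 1 and compound 3 both stand only as limits in this assay, and the step between them cannot be read. On these data alone, whether the change from carboxy to ethoxycarbonyl moves the dose in either direction stays open.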